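Swapping an Ester for an Amide: Clearance Outlook

The source may report more compounds than this note shows. Statements on the series, on what has been measured and on what is new or still open speak of the compounds shown alone.

Three compounds have been measured in an in vitro ADME assay on microsomes from liver (Homo sapiens) for metabolic stability; on this read-out lower numbers stand for slow clearance and higher numbers for fast clearance:

Compound 1 `CCOC(=O)[C@H]1CC[C@@H](n2/c(=N/C(=O)c3ccccc3)[nH]c3ccc(CN4CCCCC4)cc32)CC1` gives 222 mL.min-1.g-1.
Compound 2 `COC(=O)[C@H]1CC[C@@H](n2/c(=N/C(=O)c3ccccc3)[nH]c3ccc(CN4CCCCC4)cc32)CC1` gives 85 mL.min-1.g-1.
Compound 3 `C=CCNS(=O)(=O)c1cccc(C(=O)/N=c2\[nH]c3cc(CN4CCCCC4)ccc3n2[C@H]2CC[C@@H](CO)CC2)c1` gives 100 mL.min-1.g-1.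

Compound 2 has the lowest number of the three, but compound 3 lies within the scatter of it, so the two cannot be ordered. Compound 1 sits clearly higher: a 2.6-fold lower number from compound 1 to compound 2 (0.42 log units; beyond the scatter).

Compound 4 `CC(C)NC(=O)[C@H]1CC[C@@H](n2/c(=N/C(=O)c3ccccc3)[nH]c3ccc(CN4CCCCC4)cc32)CC1` differs from compound 2 by isopropylamino in place of methoxy on a carbonyl carbon. Going by the values given here, the only measured step, hydrogen in place of methyl on a saturated chain carbon bound to an oxygen next to a carbonyl group, touches a different part of the molecule, so it bears on this change only loosely. No firm direction is therefore expected; the number for compound 4 is estimated near that of compound 2, a step of a 1.3-fold lower number from compound 2 to compound 4 (0.12 log units; within the scatter). Compound 4 is expected to give 65 mL.min-1.g-1, within 22 mL.min-1.g-1 to 190 mL.min-1.g-1.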

Compound 4, intrinsic clearance in microsomes: 203 mL.min-1.g-1
Estimate against measurement, compound 4: 3.1-fold (0.49 log units) below, outside the stated range (above it).
By their numbers in this assay, from the lowest: compounds 2 and 3 (each within the scatter of the next); then compounds 4 and 1 (each within the scatter of the next).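

Isopropylamino in place of methoxy on the carbonyl carbon gives a 2.4-fold higher number from compound 2 to compound 4 (0.38 log units; beyond the scatter) in this assay and shows that this position responds to more than the length of the ester chain. Isopropylamino in place of ethoxy gives a 1.1-fold lower number from compound 1 to compound 4 (0.04 log units; within the scatter) and leaves the number where it was, so an amide here does not by itself bring a low number. Nothing at hand explains these results.

On these data alone, whether a methylamino group or a carboxylic acid on this carbonyl carbon would stay near the methoxy number remains open. So does whether the amide link or the branched isopropyl part matters more.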